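The source may hold more compounds than are shown below. What is called first, only, known or untested is meant among the compounds shown, and "the series" means these compounds.

Compound 1 `CC(/C=N/Nc1ccc([N+](=O)[O-])cc1)=N\NC(=O)c1ccccc1O` gives 1640 nM in a functional assay on cells (Splenocyte, Mus musculus, strain BALB/c) for inhibition, read by scintillation counting and thymidine incorporation, with a stated time of 72 h; on this read-out lower numbers stand for stronger inhibition and higher numbers for weaker inhibition. Compound 2 `CC(/C=N/Nc1ccc([N+](=O)[O-])cc1)=N\NC(=O)c1ccc(C(C)(C)C)cc1` returns only a limit in this assay, > 12000 nM. Among the measured compounds shown here, compound 3 `COc1cc(C(=O)N/N=C(C)/C=N/Nc2ccc([N+](=O)[O-])cc2)ccc1O` gives 5100 nM in this assay, the highest of the two numbers; the only step among them is a 3.1-fold higher number from compound 1 to compound 3 (0.49 log units; beyond the scatter). Compound 4 `CC(/C=N/Nc1ccc([N+](=O)[O-])cc1)=N\NC(=O)c1ccc([N+](=O)[O-])cc1` differs from compound 3 by 4-nitrophenyl in place of 4-hydroxy-3-methoxyphenyl on a carbonyl carbon. For the measured compounds named here, the one measured step at the same carbonyl carbon, a 3.1-fold higher number from compound 1 to compound 3 (0.49 log units; beyond the scatter), moved the number upward on exchange of the aryl group, and compound 2 sits at the limit of > 12000 nM in this assay, at which 1 of the 3 values shown sits. A further upward step in this assay is therefore expected for compound 4, a 1.6-fold higher number from compound 3 to compound 4 (0.20 log units; within the scatter), with a real chance of another limit. Compound 4 is estimated at 8000 nM, expected to lie between 3000 nM and 20000 nM.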

Compound 4, half-maximal inhibitory concentration: 980 nM
For compound 4 the middle estimate is 8.2-fold (0.91 log units) above the measured one; the whole stated range lies above it.
By their numbers in this assay, from the lowest: compounds 4 and 1 (each within the scatter of the next); then compound 3. At a limit, above all of these: compound 2.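

In this assay, the aryl group on the carbonyl carbon does not only push the number upward: 4-nitrophenyl in place of 4-hydroxy-3-methoxyphenyl gives a 5.2-fold lower number from compound 3 to compound 4 (0.72 log units; beyond the scatter), while in place of 2-hydroxyphenyl it gives a 1.7-fold lower number from compound 1 to compound 4 (0.22 log units; within the scatter). Nitro in place of tert-butyl on an aromatic carbon gives an at least 12-fold lower number from compound 2 to compound 4 (1.08 log units; beyond the scatter), a step read from a limit. Two unlike aryl groups, 2-hydroxyphenyl and 4-nitrophenyl, thus sit together at the low end, with compound 3 and compound 2 higher.

Still open, going by these compounds, is how an amine or a carboxylic acid on this aryl ring would read. Also open, on these data alone, is whether a saturated alkyl chain could replace the ring at the carbonyl carbon.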